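Urea Series: A Trimethoxyphenyl Variant Awaits Its Cytotoxicity Readout

A few compounds are considered here, and "the series" means these few. Any claim that something is new, unique, unknown or untested is made for them only; others in the source may bear on it.

Measured compounds so far:
compound 1, `COc1ccc(CN(C(=O)Nc2ccc(C#N)cc2)n2cnnc2)cc1OC`, > 50000 nM
compound 2, `N#Cc1ccc(CN(C(=O)Nc2cc(C(F)(F)F)cc(C(F)(F)F)c2)n2cnnc2)cc1`, 9280 nM
compound 3, `CC1CCC(NC(=O)N(Cc2ccccn2)n2cnnc2)CC1`, 33200 nM

Of the compounds shown here, three sharing one urea core have been tested in a functional assay on MDA-MB-231 cells (Homo sapiens) for cytotoxicity, read by MTT assay, with a stated time of 48 h; a lower number here means a stronger inhibitor, a higher number a weaker inhibitor. Compound 1 gives only a limit of the assay, > 50000 nM, and not a number; (the limit of > 50000 nM in this assay, at which 1 of the 3 values shown sits). Among the two compounds that do give a number, compound 2 stands lowest with 9280 nM, while compound 3 gives 33200 nM, a gap that lies beyond the usual scatter.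

The next compound, compound 4, `COc1cc(CN(C(=O)Nc2cc(C(F)(F)F)cc(C(F)(F)F)c2)n2cnnc2)cc(OC)c1OC`, keeps everything in compound 2 except one group. The change is 3,4,5-trimethoxyphenyl in place of 4-cyanophenyl on a saturated chain carbon bound to an amide-type nitrogen. Among the compounds with values here, no pair of the measured compounds differs in this one place, so the size of this step has no direct precedent.

For compound 4 the expectation is therefore wide. The step of a 1.0-fold lower number from compound 2 to compound 4 (0.01 log units; within the scatter) is expected to stay close to no change beyond the scatter, with the direction left open. Compound 4 is estimated to give 9000 nM, within a range from 2500 nM to 40000 nM.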

Compound 4, half-maximal inhibitory concentration: 24900 nM
For compound 4 the middle estimate is 2.8-fold (0.44 log units) below the measured one, within the range that was stated.
By their numbers in this assay, from the lowest: compound 2; then compounds 4 and 3 (each within the scatter of the next). At a limit, above all of these: compound 1.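

In this assay, replacing 4-cyanophenyl with 3,4,5-trimethoxyphenyl on a saturated chain carbon bound to an amide-type nitrogen gives a 2.7-fold higher number from compound 2 to compound 4 (0.43 log units; beyond the scatter). Within the data shown here, this is the first direct look at this position, and it shows that the group placed there can move the number, here towards a weaker inhibitor, while the rest of compound 2 stays the same. Both groups carry one six-membered aromatic ring of carbon only, so the ring type stays the same and the difference lies in what hangs from that ring, yet nothing shown here explains why the step has this size.

This single step cannot tell whether the shift follows from losing the nitrile, from gaining the three methoxy groups, or from both together. As far as these compounds go, a plain unsubstituted phenyl ring at the same place would help separate those two parts, and it remains open how a ring bearing a single methoxy group, an amine or a carboxylic acid would compare with compound 2 in this assay.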